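From methoxy to hydroxy in an antiproliferative series

The source may report more compounds than this note shows. Statements on the series, on what has been measured and on what is new or still open speak of the compounds shown alone.

For the measured compounds named here, in a functional assay on A2780 cells (Homo sapiens) for antiproliferative activity, read by MTT assay, with a stated time of 48 h (on this read-out lower numbers stand for stronger inhibition of growth and higher numbers for weaker inhibition of growth), compound 1 (`COC(=O)N1N=C(c2cccc(OC)c2)CC1c1cc(OC)c(OC)c(OC)c1`) gives 2780 nM and so holds the only exact number so far. For compound 2 (`COc1cccc(C2=NN(C(=O)OCc3ccccc3)C(c3cc(OC)c(OC)c(OC)c3)C2)c1`) the reading > 10000 nM is a limit and not a number. Going by the values given here, the single measured step is an at least 3.5-fold higher number from compound 1 to compound 2 (0.55 log units; beyond the scatter) and it comes from phenyl in place of hydrogen on a saturated chain carbon, away from the group changed next. Compound 3 (`COC(=O)N1N=C(c2cccc(O)c2)CC1c1cc(OC)c(OC)c(OC)c1`) keeps the core of compound 1 and alters one group: hydrogen in place of methyl on an oxygen on an aromatic ring with hydrogen in place of methyl on an oxygen on an aromatic ring. Among the compounds with values here, no measured step touches that oxygen, so the data give no size for this change, and the working guess is no shift beyond the scatter, with wide margins either way. The expected outcome is a 1.1-fold lower number from compound 1 to compound 3 (0.05 log units; within the scatter) as a rough estimate. For compound 3 the estimated value is 2500 nM with an expected range from 800 nM to 8000 nM in this assay as well.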

Compound 3, concentration for 50% growth inhibition: 810 nM
For compound 3 the middle estimate is 3.1-fold (0.49 log units) above the measured one; low and high end bracket the measured number.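

In this assay, replacing methoxy with hydroxy on the aromatic ring gives a 3.4-fold lower number from compound 1 to compound 3 (0.54 log units; beyond the scatter), a change toward stronger inhibition of growth. The earlier pair differed only at the other end of the change made here and gave no information about this oxygen, whereas the new result shows that losing a single methyl from it is enough to move the number beyond the scatter. The data shown offer no explanation for why the hydroxy compound gives the lower number.

As far as these compounds go, with only methoxy and hydroxy at this place, it remains open whether the gain is specific to hydroxy or would also appear with an amine or a fluorine there. A longer chain on the same oxygen, such as ethoxy, would show whether the number rises further as that group grows.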